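Cytotoxicity of Two Quinolones and a Piperazine Analogue

The compounds below may be only part of what the source reports. "The series", "measured", "known", "first", "only" and "open" are said of these compounds alone.

Compound 1 `CC1(CN)CCN(c2c(F)cc3c(=O)c(C(=O)O)cn(C4CC4)c3c2Cl)C1`: 8 ug/mL
Compound 2 `CNCC1(C)CCN(c2c(F)cc3c(=O)c(C(=O)O)cn(C4CC4)c3c2Cl)C1`: 23 ug/mL

In a functional assay on V79 cells (Cricetulus griseus) for cytotoxicity, read by colony formation (a higher number here means a weaker inhibitor, a lower number a stronger inhibitor), compound 1 gives 8 ug/mL, while compound 2 gives 23 ug/mL. Compound 2 therefore stands highest of the two numbers, the only other being that of compound 1, and the step of a 2.9-fold higher number from compound 1 to compound 2 (0.46 log units; beyond the scatter) is modest but beyond the scatter.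

Compound 3 `CC1CN(c2c(F)cc3c(=O)c(C(=O)O)cn(C4CC4)c3c2Cl)CCN1` is not yet measured. It differs from compound 2 by 3-methylpiperazin-1-yl in place of 3-methyl-3-((methylamino)methyl)pyrrolidin-1-yl on an aromatic carbon.

For the measured compounds named here, only one measured step exists, a 2.9-fold higher number from compound 1 to compound 2 (0.46 log units; beyond the scatter), and it concerns a methyl on an amine nitrogen rather than the exchange of one ring for another, so it bears on compound 3 only loosely. Going by the values given here, the data offer no step that matches the present change. On that thin basis compound 3 is expected to move to a somewhat higher number, with the expected step of a 2.2-fold higher number from compound 2 to compound 3 (0.34 log units; beyond the scatter) of a modest size and uncertain in direction.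

Compound 3 is therefore estimated at 50 ug/mL in this assay, within a range of 15 ug/mL to 160 ug/mL.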

Compound 3, half-maximal inhibitory concentration: 45 ug/mL
Compound 3: middle estimate off by 1.1-fold (0.05 log units), on the high side, and the stated range covers the measured number.
By their numbers in this assay, from the lowest: compound 1; then compounds 2 and 3 (each within the scatter of the next).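

In this assay, placing 3-methylpiperazin-1-yl instead of 3-methyl-3-((methylamino)methyl)pyrrolidin-1-yl on this aromatic carbon, ortho to the chloro and fluoro groups, gives a 2.0-fold higher number from compound 2 to compound 3 (0.29 log units; within the scatter) and so does not separate the two groups in this assay. Set against the 3-(aminomethyl)-3-methylpyrrolidin-1-yl group, the same piperazine gives a 5.6-fold higher number from compound 1 to compound 3 (0.75 log units; beyond the scatter) and shows that this position can register a change of ring, a comparison the earlier pair could not offer. No measurement at hand accounts for either step.

The compounds shown leave open how a piperazin-1-yl group without its methyl, or a 3-aminopyrrolidin-1-yl group, would read at this carbon. They also leave open whether these steps would hold with a methoxy group in place of the chloro group.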